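A Second Methyl After a Steep Loss of Growth Inhibition

This account rests on a few compounds, and the source may have more. Where it says the series, first, only, none or still open, it means among the compounds named here.

In a functional assay on K562 cells (Homo sapiens) for inhibition, read by trypan blue exclusion, with a stated time of 24 h, tested at 10 uM (a lower number here means less inhibition of growth, a higher number more inhibition of growth at the concentration tested), compound 1 (`NC(=O)c1ccccc1NC(=O)COc1ccccc1`) gives 57.4%. Compound 2 (`Cc1ccc(OCC(=O)Nc2ccccc2C(N)=O)cc1`) reads < 10% in this assay, and that reading is a limit of the assay and not a number. Compound 2 therefore stands at the limit of < 10% in this assay, at which 1 of the 2 values shown sits, with no exact figure to start from.

Compound 3 (`Cc1ccc(OCC(=O)Nc2ccc(C)cc2C(N)=O)cc1`) carries one further methyl on compound 2: methyl in place of hydrogen on an aromatic carbon. For the measured compounds named here, only one measured step bears on this change, since it too places methyl in place of hydrogen on an aromatic carbon. That step is a number at least 47.4 percentage points lower from compound 1 to compound 2 (beyond the scatter), a large fall. It is a single case, and the new methyl does not repeat its placement, so its size cannot simply be carried over. Going by the values given here, still, with a number at least 47.4 percentage points lower from compound 1 to compound 2 (beyond the scatter) as the only guide, nothing in the data points to a recovery, and compound 3 is expected to remain weak. The expected change is a number at least 2 percentage points higher from compound 2 to compound 3 (that floor lies within the scatter), most likely no step beyond the scatter, though a modest rise remains possible. In this assay, the estimated value for compound 3 is 12%, within an expected range of 0% to 35%.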

Compound 3, percent growth inhibition at one concentration: 30.3%
Compound 3: middle estimate off by 18.3 percentage points, on the low side; the measured number falls inside the stated range.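

In this assay, methyl in place of hydrogen on an aromatic carbon is no longer seen only as a loss: placed meta to a carbamoyl group and para to a large group, the change gives a number at least 20.3 percentage points higher from compound 2 to compound 3 (beyond the scatter), whereas its only earlier case gave a number at least 47.4 percentage points lower from compound 1 to compound 2 (beyond the scatter). Across these two steps, the same exchange of hydrogen for methyl moves the read-out in opposite directions at two different places, so the direction of the first step does not carry over to this position. The rise has a floor but no exact size, because its starting point is a limit of the assay and not a number: the limit of < 10% in this assay, at which 1 of the 3 values shown sits.

The compounds shown leave open whether the rise belongs to methyl in particular or would also follow from another group at this position, such as chlorine, methoxy or an amine. They also leave open whether the same methyl would give a comparable step on the core of compound 1, where the methyl that compound 2 carries is absent.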